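Carboxy in Place of Hydroxymethyl: Little Inhibition Expected

The compounds below may be only part of what the source reports. "The series", "measured", "known", "first", "only" and "open" are said of these compounds alone.

Measured compounds:
compound 1 `O=C(NO)c1ccc(-c2cn([C@@H]3C[C@@H](C(=O)O)N(Cc4ccccc4)C3)nn2)cc1` — < 10%
compound 2 `O=C(NO)c1ccc(-c2cn([C@@H]3C[C@H](CO)N(Cc4ccccc4)C3)nn2)cc1` — 14%

Two hydroxamic acids were tested in an assay on Sf9 cells for inhibition of histone deacetylase 11 (Homo sapiens), read by fluorescence, tested at 0.5 uM; on this read-out higher numbers stand for more inhibition at the one concentration tested (going by the name of the read-out) and lower numbers for less inhibition. Within the data shown here, compound 2 `O=C(NO)c1ccc(-c2cn([C@@H]3C[C@H](CO)N(Cc4ccccc4)C3)nn2)cc1` gives 14%, and it is the only plain number among the two values shown. For compound 1 `O=C(NO)c1ccc(-c2cn([C@@H]3C[C@@H](C(=O)O)N(Cc4ccccc4)C3)nn2)cc1` the read-out is a limit of the assay, < 10%. Among the measured compounds shown here, the two measured compounds do not differ in a single place, so no measured step between them is known.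

The unmeasured compound 3 `O=C(NO)c1ccc(-c2cn([C@@H]3C[C@H](C(=O)O)N(Cc4ccccc4)C3)nn2)cc1` differs from compound 2 by carboxy in place of hydroxymethyl on a saturated ring carbon. A carboxy group also appears in compound 1, whose value sits at the limit of the assay, (the limit of < 10% in this assay, at which 1 of the 2 values shown sits).

Without a measured step for a change of this kind, the writer expects the step from compound 2 to compound 3 to be small, a number 6 percentage points lower from compound 2 to compound 3 (within the scatter), downward or none beyond the scatter. Compound 3 is therefore estimated to give 8%, with the range from 0% to 20%, and a fair chance that this assay reports only a limit for it.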

Compound 3, a percentage reported as inhibition, at one concentration (the size of the read-out at that concentration, not a potency): < 10%
Compound 3: a limit, no number; the forecaster's own chance of this, stated with the estimate: 55%; the middle value does not contradict the limit.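

In this assay, among these compounds, carboxy in place of hydroxymethyl on this saturated ring carbon gives a number at least 4 percentage points lower from compound 2 to compound 3 (that floor lies within the scatter), the only readable step at this position, and its true size remains unfixed. Compound 3 gives a limit of the assay, < 10%, not a number. Compound 1 alone could show a carboxy group at the limit in only one drawn configuration, whereas compound 3 now shows the same kind of read-out in the other: the fact that compounds 1 and 3 differ only in the configuration as drawn.

On these data alone, the step between these two carboxy compounds cannot be read, so any effect of configuration on inhibition stays open: the limit of < 10% in this assay, at which 2 of the 3 values shown sit. The compounds shown also do not tell whether an amine, a methyl ester or a longer chain on this ring carbon would give a plain number in this assay, or whether the hydroxymethyl group of compound 2 would give a different read-out in the other configuration.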